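The source may report more compounds than this note shows. Statements on the series, on what has been measured and on what is new or still open speak of the compounds shown alone.

Working notes on the series: in a functional assay on HepG2 cells (Homo sapiens) for cytotoxicity, read by MTT assay, with a stated time of 24 h (on this read-out lower numbers stand for stronger inhibition and higher numbers for weaker inhibition), compound 1 (`COc1cc(/C=C2\CN(C)C/C(=C\c3ccc(Cl)cc3Cl)C2=O)cc(OC)c1OC`) gives 8800 nM and compound 2 (`CN1C/C(=C\c2ccc(Cl)cc2)C(=O)/C(=C/c2cccc([N+](=O)[O-])c2)C1`) gives 8210 nM. These two numbers lie within the usual scatter of each other, so compound 2 cannot be separated from compound 1. Compound 3 (`CN1C/C(=C\c2cccc([N+](=O)[O-])c2)C(=O)/C(=C/c2ccc(Cl)cc2Cl)C1`) differs from compound 2 in one place: chloro in place of hydrogen on an aromatic carbon. This is chloro in place of hydrogen on an aromatic carbon, which turns 4-chlorophenyl into 2,4-dichlorophenyl. Going by the values given here, no measured pair in this set isolates that change. Compound 1 also carries 2,4-dichlorophenyl and gives 8800 nM, which offers no sign of a large shift in this assay. A change no larger than the scatter is expected, without a firm direction, and the estimated step is a 1.2-fold lower number from compound 2 to compound 3 (0.07 log units; within the scatter). For compound 3 the expected value is 7000 nM, with an estimated range of 3000 nM to 16000 nM.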

Compound 3, half-maximal inhibitory concentration: 4800 nM
For compound 3 the middle estimate is 1.5-fold (0.16 log units) above the measured one; measured number inside the range.
By their numbers in this assay, from the lowest: compounds 3, 2 and 1 (each within the scatter of the next).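

In this assay, going by these compounds alone, the first pair to isolate this change gives a 1.7-fold lower number from compound 2 to compound 3 (0.23 log units; within the scatter), so adding chloro ortho to a large group, which turns 4-chlorophenyl into 2,4-dichlorophenyl, cannot be told apart from no effect. The position therefore accepts this one added chlorine with no shift beyond the scatter, at least with the partner aromatic group of compound 2 and compound 3 held fixed. No supporting measurement bears on why this step has this size.

Open, from the compounds shown here alone, is whether a fluoro group, an amine or a carboxylic acid at the same position would also stay within the scatter. The compounds shown also leave open whether the same step would hold on a different partner aromatic group, as this change is read from a single pair.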